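Piperazine aryl group and receptor binding

The source may report more compounds than this note shows. Statements on the series, on what has been measured and on what is new or still open speak of the compounds shown alone.

Binding in an assay on HEK293 cells for displacement of a labelled ligand from 5-hydroxytryptamine receptor 7 (Homo sapiens); a lower number here means a stronger inhibitor, a higher number a weaker inhibitor:
compound 1 `COc1ccccc1N1CCN(Cc2ccc(CN3C(=O)c4ccccc4S3(=O)=O)cc2)CC1`: 97 nM
compound 2 `COc1ccccc1N1CCN(CCCCCN2C(=O)c3ccccc3S2(=O)=O)CC1`: 125 nM
compound 3 `O=C1c2ccccc2S(=O)(=O)N1CCCCCN1CCN(c2ncccn2)CC1`: 2670 nM

Compound 3 gives the highest number of the three in this assay, well beyond the scatter from both others, the step of a 21-fold higher number from compound 2 to compound 3 (1.33 log units; beyond the scatter) showing how much the pyrimidinyl costs. Compound 4 `O=C1c2ccccc2S(=O)(=O)N1CCCCCN1CCN(c2cccc3ccccc23)CC1` is not yet measured; it differs from compound 3 by naphthalen-1-yl in place of pyrimidin-2-yl on an amine nitrogen in a ring. For the measured compounds named here, only one measured step bears on this position, and it is large. Compound 4 is expected to move back toward the carbocyclic aryl analogues because a 21-fold higher number from compound 2 to compound 3 (1.33 log units; beyond the scatter) went the other way, so a large decrease is expected, an 18-fold lower number from compound 3 to compound 4 (1.25 log units; beyond the scatter). Compound 4 is estimated at 150 nM in this assay, range 40 nM to 600 nM.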

Compound 4, inhibition constant: 36 nM
Compound 4: middle estimate off by 4.2-fold (0.62 log units), on the high side; the measured number lies below the stated range.
By their numbers in this assay, from the lowest: compound 4; then compounds 1 and 2 (each within the scatter of the next); then compound 3.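

Naphthalen-1-yl more than recovers what pyrimidin-2-yl loses at this position on the piperazine-type amine nitrogen (a 74-fold lower number from compound 3 to compound 4 (1.87 log units; beyond the scatter)). It also goes past the 2-methoxyphenyl group in this assay (a 3.5-fold lower number from compound 2 to compound 4 (0.54 log units; beyond the scatter)), so this position accepts two six-membered aromatic rings of carbon only, with no hydrogen-bond acceptors. Nothing at hand explains either step.

Open, from the compounds shown here alone, is whether an unsubstituted phenyl or a quinolinyl group would follow naphthalen-1-yl or pyrimidin-2-yl. Also open, going by these compounds, is whether naphthalen-1-yl gives the same gain on the linker of compound 1.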